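This account rests on a few compounds, and the source may have more. Where it says the series, first, only, none or still open, it means among the compounds named here.

Measured compounds in an ADME assay on L02 cells (Homo sapiens) for cytotoxicity, read by MTT assay, with a stated time of 48 h; on this read-out lower numbers stand for stronger inhibition and higher numbers for weaker inhibition:

- compound 1 `CN1CCN(C[C@H]2CN(c3ccc(-n4cc(-c5ccccn5)cn4)c(F)c3)C(=O)O2)CC1`: 70 ug/mL
- compound 2 `O=C1CSC(=O)N1C[C@H]1CN(c2ccc(-n3cc(-c4ccccn4)cn3)c(F)c2)C(=O)O1`: the value is a limit, > 400 ug/mL
- compound 3 `CC(=O)OC[C@H]1CN(c2ccc(-n3cc(-c4ccccn4)cn3)c(F)c2)C(=O)O1`: the value is a limit, > 400 ug/mL

Compound 3 stands at the limit of this assay; the number reported for it is a limit and not a measured value. It shares that position with compound 2, as noted in the limit of > 400 ug/mL in this assay, at which 2 of the 3 values shown sit. Only compound 1 gives a measured number in this assay.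

The step to compound 4 `O=C1O[C@@H](Cn2ccnc2)CN1c1ccc(-n2cc(-c3ccccn3)cn2)c(F)c1` is 1H-imidazol-1-yl in place of acetoxy on a saturated chain carbon bound to a saturated ring carbon.

For the measured compounds named here, two measured steps bear on it indirectly. Both leave the 4-methylpiperazin-1-yl of compound 1 and land at the limit: an at least 5.7-fold higher number from compound 1 to compound 2 (0.75 log units; beyond the scatter) and an at least 5.7-fold higher number from compound 1 to compound 3 (0.75 log units; beyond the scatter). The step between the two limit compounds is a step that the two limits leave unreadable from compound 2 to compound 3, so the data give no reading on how one group at this chain carbon compares with another once compound 1 is left behind. Both replacements of the 4-methylpiperazin-1-yl so far, in compound 2 and compound 3, gave only limits.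

On this basis compound 4 is expected to stay weak in this assay, with a fair chance of another limit; the step of an at least 1.3-fold lower number from compound 3 to compound 4 (0.12 log units; that floor lies within the scatter) is estimated as not readable beyond the scatter. The estimate for compound 4 is 300 ug/mL, with a range from 120 ug/mL to 600 ug/mL.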

Compound 4, half-maximal inhibitory concentration: 350 ug/mL
Estimate against measurement, compound 4: 1.2-fold (0.07 log units) below; low and high end bracket the measured number.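

For the compounds shown here, with 1H-imidazol-1-yl on the saturated chain carbon bound to a saturated ring carbon, compound 4 gives the first measured number in this assay for any group other than 4-methylpiperazin-1-yl, so leaving compound 1 now has a readable size: a 5.0-fold higher number from compound 1 to compound 4 (0.70 log units; beyond the scatter). The five-membered aromatic ring is not separated from the acetoxy or the 2,4-dioxo-1,3-thiazolidin-3-yl, since the floors of an at least 1.1-fold lower number from compound 3 to compound 4 (0.05 log units; that floor lies within the scatter) and an at least 1.1-fold lower number from compound 2 to compound 4 (0.05 log units; that floor lies within the scatter) establish no difference beyond the scatter. Compound 2 and compound 3 remain limits and not numbers, and the step between them cannot be read: the limit of > 400 ug/mL in this assay, at which 2 of the 4 values shown sit.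

All three replacements shown sit on the high-number side of compound 1, but one compound alone carries the 4-methylpiperazin-1-yl, so the lower number cannot yet be tied to any particular part of that group. A morpholin-4-yl or an open-chain dimethylamino group at this chain carbon would test whether the lower number stays with the ring, with the ring's second nitrogen or with an amine as such.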